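A few compounds are considered here, and "the series" means these few. Any claim that something is new, unique, unknown or untested is made for them only; others in the source may bear on it.

Three compounds on the shared core differ only in one group on an aromatic carbon, and all are read in a physicochemical assay for lipophilicity, measured as octanol-water partition, at pH 7.4; on this read-out higher numbers stand for higher lipophilicity and lower numbers for lower lipophilicity. In this assay compound 1 `CC(C)c1noc(N2CCC(Oc3cc(N4CCc5cc(C6CCCCC6=O)ccc54)ncn3)CC2)n1` gives 4.7, compound 2 `CC(C)c1noc(N2CCC(Oc3cc(N4CCc5cc(N6CC(O)CCC6=O)ccc54)ncn3)CC2)n1` gives 2.6 and compound 3 `CC(C)c1noc(N2CCC(Oc3cc(N4CCc5cc(N6CCOCC6=O)ccc54)ncn3)CC2)n1` gives 3.1. Compound 3 therefore holds the second highest of the three numbers, closer to compound 2 than to compound 1.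

The next compound is compound 4 `CC(C)c1noc(N2CCC(Oc3cc(N4CCc5cc(S(C)(=O)=O)ccc54)ncn3)CC2)n1`, with methylsulfonyl in place of 3-oxomorpholin-4-yl on an aromatic carbon.

Two measured steps are large, a number 2.10 log units lower from compound 1 to compound 2 (beyond the scatter) and a number 1.60 log units lower from compound 1 to compound 3 (beyond the scatter), but both leave 2-oxocyclohexyl, a group not involved in this change. The step that bears most closely is a number 0.50 log units higher from compound 2 to compound 3 (beyond the scatter), which is modest and exchanges one ring group for another. Among the compounds with values here, no measured step replaces a ring at this place with an open group, so the direction remains uncertain. The size of the step from compound 2 to compound 3 sets the likely scale, and no step beyond the scatter is expected in this assay. The expected step is a number 0.10 log units higher from compound 3 to compound 4 (within the scatter). For compound 4 the estimated value is 3.2, with an expected range of 2.7 to 3.7.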

Compound 4, distribution coefficient: 3.1
For compound 4 the middle estimate is 0.10 log units above the measured one; measured number inside the range.
By their numbers in this assay, from the lowest: compound 2; then compounds 3 and 4 (each within the scatter of the next); then compound 1.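

Methylsulfonyl is the first group without a ring at this aromatic carbon, and in this assay the exchange for 3-oxomorpholin-4-yl gives no change at the digits printed from compound 3 to compound 4 (within the scatter) despite the loss of the ring and the smaller heavy-atom count, while the hydrogen-bond donor and acceptor counts stay the same. Against the other two compounds, the open group gives a number 0.50 log units higher from compound 2 to compound 4 (beyond the scatter) and a number 1.60 log units lower from compound 1 to compound 4 (beyond the scatter) and so takes the same place in the series as compound 3: a ring at this position is not needed for a number in this part of the range, at least for this one open group. Nothing available accounts for methylsulfonyl and 3-oxomorpholin-4-yl reading alike.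

From the compounds shown here alone, whether other open groups at this aromatic carbon, such as an amine, a carboxylic acid or a longer chain on the sulfonyl, would also read alike with compound 3 in this assay stays open. Going by these compounds, how compound 3 and compound 4 compare on any other read-out also stays open.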